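The source may report more compounds than this note shows. Statements on the series, on what has been measured and on what is new or still open speak of the compounds shown alone.

Series notes, cyclopropane amides bearing the trimethoxyphenyl unit, read in a functional assay on A549 cells (Homo sapiens) for cytotoxicity, read by MTT assay, with a stated time of 48 h; on this read-out lower numbers stand for stronger inhibition and higher numbers for weaker inhibition.

Two diastereomers carry 2-chlorophenyl on the amide nitrogen. Compound 1 `CCOC(=O)[C@]1(C(=O)Nc2ccccc2Cl)C[C@@H]1c1cc(OC)c(OC)c(OC)c1` gives 50900 nM in this assay. Compound 2 `CCOC(=O)[C@@]1(C(=O)Nc2ccccc2Cl)C[C@H]1c1cc(OC)c(OC)c(OC)c1` gives 17600 nM in this assay. Within the data shown here, the step of a 2.9-fold lower number from compound 1 to compound 2 (0.46 log units; beyond the scatter) is the only measured step in the set, and it rests on the fact that compounds 1 and 2 differ only in the configuration as drawn alone, with no change of atoms or bonds.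

Compound 3 `CCOC(=O)[C@@]1(C(=O)NCc2ccc(C)cc2)C[C@@H]1c1cc(OC)c(OC)c(OC)c1` carries 4-methylbenzyl on the amide nitrogen instead. In this assay compound 3 gives only a limit, > 100000 nM, and no number; this is the limit of > 100000 nM in this assay, at which 1 of the 3 values shown sits, and it places compound 3 at the weak end of everything shown.

Compound 4 `CCOC(=O)[C@@]1(C(=O)Nc2ccccc2Cl)C[C@@H]1c1cc(OC)c(OC)c(OC)c1` is not yet measured. Relative to compound 3 the change is 2-chlorophenyl in place of 4-methylbenzyl on an amide-type nitrogen. Among the measured compounds shown here, no measured step covers this exchange on the amide nitrogen; the one step available concerns configuration only, so its size is no direct guide here. What does bear is that both compounds carrying 2-chlorophenyl return numbers rather than a limit, so compound 4 is expected to move to a lower number than compound 3 in this assay, by about an at least 2.5-fold lower number from compound 3 to compound 4 (0.39 log units; beyond the scatter). Compound 4 is estimated at 40000 nM, within 10000 nM to 150000 nM.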

Compound 4, half-maximal inhibitory concentration: 29000 nM
Estimate against measurement, compound 4: 1.4-fold (0.14 log units) above; measured number inside the range.
By their numbers in this assay, from the lowest: compounds 2, 4 and 1 (each within the scatter of the next, the first and the last beyond it). At a limit, above all of these: compound 3.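

In this assay, among these compounds, the exchange of 4-methylbenzyl for 2-chlorophenyl on the amide-type nitrogen, with the configuration as drawn held, gives the first step that reads across this position, an at least 3.4-fold lower number from compound 3 to compound 4 (0.53 log units; beyond the scatter), and this step is only a bound since one end of it is a limit and not a number. The step of a 1.6-fold higher number from compound 2 to compound 4 (0.22 log units; within the scatter) and the step of a 1.8-fold lower number from compound 1 to compound 4 (0.24 log units; within the scatter) both stay within the scatter, so the configuration at one stereocentre alone gives no readable change in either case. Only compounds 1 and 2, with both stereocentres inverted, stand beyond the scatter of each other, and the two new comparisons are purely matters of configuration: the fact that compounds 1 and 4 differ only in the configuration as drawn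

The exchange alters the link to the nitrogen and the ring substituent together, so the compounds shown do not tell which of the two carries the step; 2-chlorobenzyl or plain phenyl on the same nitrogen would part them. Also open, from the compounds shown here alone, are whether the 4-methylbenzyl amide stays at the limit in other configurations and how a carboxylic acid in place of the ethyl ester would read.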